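Swapping Amino for Methoxy in a Cytotoxic Series

The source may hold more compounds than are shown below. What is called first, only, known or untested is meant among the compounds shown, and "the series" means these compounds.

Compound 1 `COc1cc(-c2cc(/C=C/C(=O)c3ccc(N)cc3)[nH]n2)cc(OC)c1OC` was tested in a functional assay on OVCAR-4 cells (Homo sapiens) for cytotoxicity, read by sulforhodamine B assay, with a stated time of 48 h, tested at 100 uM (a lower number here means a stronger effect, a higher number a weaker effect of the compound at the concentration tested), where compound 1 gives -96%. Its companion compound 2 `COc1ccc(-c2cc(/C=C/C(=O)c3ccc(N)cc3)[nH]n2)cc1OC` gives -98% in this assay, and the two numbers sit within the usual scatter of each other. The step of a number 2 percentage points lower from compound 1 to compound 2 (within the scatter) comes from hydrogen in place of methoxy on an aromatic carbon and leaves the read-out essentially where it was.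

Compound 3 `COc1ccc(C(=O)/C=C/c2cc(-c3cc(OC)c(OC)c(OC)c3)n[nH]2)cc1` arises from compound 1 by a different change, (methoxy in place of amino on an aromatic carbon). Among the measured compounds shown here, no measured step touches this position, so the one known step bears on it only by showing that a change elsewhere did not move the number beyond the scatter. Because compound 1 gives -96%, with little room left to move further, compound 3 is expected to stay near it, and the expected step is a number 6 percentage points higher from compound 1 to compound 3 (within the scatter). For compound 3 the estimate in this assay is -90%, with a range from -100% to -60%.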

Compound 3, a percentage reported as activity, at one concentration (the size of the read-out at that concentration, not a potency): -15%
For compound 3 the middle estimate is 75 percentage points below the measured one; the whole stated range lies below it.
By their numbers in this assay, from the lowest: compounds 2 and 1 (each within the scatter of the next); then compound 3.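

In this assay, the swap from 4-aminophenyl to 4-methoxyphenyl gives a number 81 percentage points higher from compound 1 to compound 3 (beyond the scatter) and so has a far greater effect than the earlier change, which gave a number 2 percentage points lower from compound 1 to compound 2 (within the scatter) on the other aromatic ring. The read-out is therefore sensitive to what sits at this place on the six-membered aromatic ring, para to a large group, and most of the strong effect of compound 1 is lost with this single swap. Nothing available here accounts for the size of this step.

From the compounds shown here alone, it remains open whether another group at this place, such as a hydroxyl, a methylamino or a dimethylamino group, would keep the effect or lose it as methoxy does. Going by these compounds, it is also open whether the same swap on compound 2 would produce a similar loss.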